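Ethoxy to methoxy on the aromatic ring

This account rests on a few compounds, and the source may have more. Where it says the series, first, only, none or still open, it means among the compounds named here.

For the measured compounds named here, in a functional assay on HeLa cells (Homo sapiens) for inhibition, read by sulforhodamine B assay (a lower number here means a stronger inhibitor, a higher number a weaker inhibitor), compound 1 (`CCc1ccc(NC2=CC(=O)c3nc4n(c3C2=O)[C@H]2OC[C@@H](O)[C@H]2OC4)cc1`) gives 3990 nM and compound 2 (`CCOc1ccc(NC2=CC(=O)c3nc4n(c3C2=O)[C@H]2OC[C@@H](O)[C@H]2OC4)cc1`) gives 3110 nM, so compound 2 stands within the scatter of the only other measured value. Compound 3 (`COc1ccc(NC2=CC(=O)c3nc4n(c3C2=O)[C@H]2OC[C@@H](O)[C@H]2OC4)cc1`) differs from compound 2 by hydrogen in place of methyl on a saturated chain carbon bound to an oxygen on an aromatic ring. Going by the values given here, the one measured step that bears on this is a 1.3-fold lower number from compound 1 to compound 2 (0.11 log units; within the scatter), ethoxy in place of ethyl. No shift beyond the scatter is therefore expected in this assay, with an expected 1.1-fold higher number from compound 2 to compound 3 (0.03 log units; within the scatter). Compound 3 is estimated at 3300 nM, with an expected range of 1500 nM to 7000 nM.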

Compound 3, half-maximal inhibitory concentration: 4780 nM
Beside the measured number, compound 3's estimate is 1.4-fold (0.16 log units) below it; low and high end bracket the measured number.
By their numbers in this assay, from the lowest: compounds 2, 1 and 3 (each within the scatter of the next).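

In this assay, 4-methoxyphenyl in place of 4-ethoxyphenyl gives a 1.5-fold higher number from compound 2 to compound 3 (0.19 log units; within the scatter), and methoxy in place of ethyl gives a 1.2-fold higher number from compound 1 to compound 3 (0.08 log units; within the scatter). Ethyl, ethoxy and methoxy on this aromatic carbon therefore all read alike, and removing the terminal methyl of the ethoxy group does not separate compound 3 from compound 2. No evidence bears on this result.

From the compounds shown here alone, whether an amine, a carboxylic acid or a longer chain on this aromatic carbon would move the number beyond the scatter remains open.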